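The source may report more compounds than this note shows. Statements on the series, on what has been measured and on what is new or still open speak of the compounds shown alone.

Cytotoxicity set, read in an ADME assay on HEL cells (Homo sapiens) for cytotoxicity, with a stated time of 3 days; on this read-out higher numbers stand for lower toxicity in this test and lower numbers for higher toxicity in this test.
Compound 1 `O=S1(=O)C=C(OCc2ccccc2)C(Cc2ccccc2)(Cc2ccccc2)O1`: 200000 nM.
Compound 2 `CCC1(Cc2ccccc2)OS(=O)(=O)C=C1OCc1ccc([N+](=O)[O-])cc1`: >= 80000 nM, a limit of the assay rather than a number.
Compound 3 `CCC1(Cc2ccccc2)OS(=O)(=O)C=C1OCc1ccc(OC)cc1`: >= 200000 nM, also a limit of the assay rather than a number.

Compound 2 stands only at a limit in this assay, with no number behind it, at the limit of >= 80000 nM in this assay, at which 1 of the 3 values shown sits. Going by the values given here, compound 3 is the one further value that is a limit, at the limit of >= 200000 nM in this assay, at which 1 of the 3 values shown sits. Among the compounds with values here, the single step with one structural change, a step that the two limits leave unreadable from compound 2 to compound 3, has no readable size; both of its ends are limits. The change now followed, from compound 2 to compound 4 `CCC1(Cc2ccccc2)OS(=O)(=O)C=C1OC`, is hydrogen in place of 4-nitrophenyl on a saturated chain carbon bound to an oxygen on an unsaturated carbon. Within the data shown here, no measured step bears on this change with a readable size, and none of the three values shows toxicity inside the tested range. No step beyond the scatter is therefore expected in this assay, in either direction; compound 4 is expected to sit near the upper edge of the tested range, most likely again as a limit. The estimate for compound 4 is 200000 nM, within 80000 nM to 400000 nM. The step this estimate means, a step that the limit leaves unreadable from compound 2 to compound 4, is expected to lie within the scatter.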

Compound 4, minimum cytotoxic concentration: > 400000 nM
Compound 4 gave a limit, no number; the forecaster's own chance of this, stated with the estimate: 70%; middle value at least 2.0-fold (0.30 log units) away from the limit.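

In this assay compound 4 gives > 400000 nM, a limit and not a number. Compound 2 and compound 3 also stand only at limits, so neither step to compound 4 can be read. Going by these compounds, whether hydrogen in place of 4-nitrophenyl or 4-methoxyphenyl shifts this read-out at all remains open.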